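The source may hold more compounds than are shown below. What is called first, only, known or untested is meant among the compounds shown, and "the series" means these compounds.

Measured so far:
- compound 1 `O=C(c1cccnc1)c1cc(F)ccc1O`: 12000 nM
- compound 2 `O=C(c1cccnc1)c1ccccc1O`: 31000 nM
- compound 3 `O=C(c1cccnc1)c1cc(Cl)cc(Cl)c1O`: 27000 nM

All three were tested in a functional assay on Hep cells (Homo sapiens) for cytotoxicity, read by sulforhodamine B assay, with a stated time of 48 h; a lower number here means a stronger inhibitor, a higher number a weaker inhibitor. Compound 3 cannot be told apart from compound 2, since their values lie within the usual scatter. Compound 1 shows the lower number, and its gap to compound 3 is beyond the scatter.

The next compound is compound 4 `O=C(c1cccnc1)c1cc(Cl)ccc1O`, which has hydrogen in place of chloro on an aromatic carbon, ortho to a hydroxy group (hydrogen in place of chloro on an aromatic carbon). Among the compounds with values here, no measured step makes exactly this swap. The closest is a modest one, a 2.6-fold higher number from compound 1 to compound 2 (0.41 log units; beyond the scatter), in which hydrogen replaces fluoro. That step cannot simply be copied, because compound 2 at 31000 nM carries neither group and still matches compound 3. Compound 4 keeps a chloro group, much as compound 1 at 12000 nM keeps a fluoro group, so a small move towards a lower number is expected. The expected change is a 1.7-fold lower number from compound 3 to compound 4 (0.23 log units; within the scatter). For compound 4 the estimated value is 16000 nM, with an expected range of 8000 nM to 32000 nM.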

Compound 4, half-maximal inhibitory concentration: 27000 nM
Beside the measured number, compound 4's estimate is 1.7-fold (0.23 log units) below it; measured number inside the range.
By their numbers in this assay, from the lowest: compound 1; then compounds 3, 4 and 2 (each within the scatter of the next).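

In this assay, taking away the chloro group ortho to a hydroxy group gives no change at the digits printed from compound 3 to compound 4 (within the scatter), so this position tolerates either chloro or hydrogen with no readable difference. The chloro group that compound 4 keeps makes no readable difference either, with a 1.1-fold lower number from compound 2 to compound 4 (0.06 log units; within the scatter), while swapping it for fluoro in that same place gives a 2.3-fold higher number from compound 1 to compound 4 (0.35 log units; beyond the scatter), which leaves compound 1 as the only one of the four set apart from the rest. No measured evidence here accounts for this result.

As far as these compounds go, whether a methoxy group or an amine in place of the chloro group ortho to a hydroxy group would shift the number stays open. So does whether the lower number of compound 1 is particular to fluoro or would also appear with another group in that place, such as a nitrile.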